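The source may report more compounds than this note shows. Statements on the series, on what has been measured and on what is new or still open speak of the compounds shown alone.

Series notes. Compound 1 `Fc1cccc(F)c1/C=N/NC(=S)Nc1cccc2ccccc12` and compound 2 `Fc1cc(F)c(/C=N/NC(=S)Nc2cccc3ccccc23)c(F)c1` share one core. In an ADME assay on NIH3T3 cells (Mus musculus) for cytotoxicity, read by XTT assay, with a stated time of 24 h (on this read-out lower numbers stand for stronger inhibition and higher numbers for weaker inhibition), compound 1 gives 31.3 ug/mL. For compound 2 the read-out in this assay is a limit of the assay, > 500 ug/mL, so compound 2 stands at the edge of the numbers shown, without an exact figure. Going by the values given here, the one measured step, an at least 15-fold higher number from compound 1 to compound 2 (1.20 log units; beyond the scatter), is therefore only a bound, set by the limit of > 500 ug/mL in this assay, at which 1 of the 2 values shown sits.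

Compound 3 `Fc1ccc(/C=N/NC(=S)Nc2cccc3ccccc23)c(F)c1` is still to be measured. Its change from compound 2 is hydrogen in place of fluoro on an aromatic carbon. Among the compounds with values here, a different fluoro leaves than the one that entered from compound 1 to compound 2, so compound 3 is not compound 1, but the only measured step runs in the opposite direction and was large, so removing a fluoro is expected to lower the number again, by an uncertain amount. Compound 3 is estimated at 100 ug/mL in this assay, within 30 ug/mL to 500 ug/mL, which means an expected step of an at least 5.0-fold lower number from compound 2 to compound 3 (0.69 log units; beyond the scatter).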

Compound 3, half-maximal inhibitory concentration: > 500 ug/mL
Compound 3: only a limit was reported; the forecaster's own chance of this, stated with the estimate: 30%; middle value at least 5.0-fold (0.69 log units) from the limit.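

In this assay, the step between compound 2 and compound 3, hydrogen in place of fluoro on an aromatic carbon, cannot be read, as both values are limits of the assay. The new information is that this fluoro, ortho to a large group, is not required for the read-out to reach that limit, as compound 3 reaches it without the fluoro. Exchanging 2,6-difluorophenyl for 2,4-difluorophenyl alone gives an at least 15-fold higher number from compound 1 to compound 3 (1.20 log units; beyond the scatter), and this step is again only a bound: the limit of > 500 ug/mL in this assay, at which 2 of the 3 values shown sit.

On these data alone, how far compound 2 and compound 3 lie beyond the limit remains open. Also open, as far as these compounds go, is whether an amine or a methoxy group on this aromatic carbon would bring the read-out in this assay back into the measurable range.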